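This account rests on a few compounds, and the source may have more. Where it says the series, first, only, none or still open, it means among the compounds named here.

Compound 1, `CCC(=O)Nc1c(C(O)(C(F)(F)F)C(F)(F)F)ccc2ccccc12`, gives 8.91 nM.
Compound 2, `O=C(Nc1c(C(O)(C(F)(F)F)C(F)(F)F)ccc2ccccc12)C1CCC1`, gives 81.3 nM.
Compound 3, `COCC(=O)Nc1c(C(O)(C(F)(F)F)C(F)(F)F)ccc2ccccc12`, gives 204 nM.

These three compounds share one core and were tested in a functional assay (Sus scrofa) with sulfonylurea receptors; K-ATP channels (Homo sapiens) as the target; a higher number here means that more compound is needed for the effect, a lower number that less compound is needed. Compound 1 stands at the lowest of the three numbers, so it needs the least compound for the effect. Compound 2 differs from it only by cyclobutyl in place of ethyl on a carbonyl carbon, and that step reads a 9.1-fold higher number from compound 1 to compound 2 (0.96 log units; beyond the scatter). Compound 3 differs only by methoxy in place of methyl on a saturated chain carbon bound to a carbonyl carbon, and that step reads a 23-fold higher number from compound 1 to compound 3 (1.36 log units; beyond the scatter).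

Compound 4, `O=C(Nc1c(C(O)(C(F)(F)F)C(F)(F)F)ccc2ccccc12)c1cccc(Cl)c1`, has not yet been measured. Its difference from compound 1 is 3-chlorophenyl in place of ethyl on a carbonyl carbon. Both measured changes away from the ethyl of compound 1 gave higher numbers, one modest and one large, so a change that puts a group containing an aromatic ring in place of the ethyl chain is expected to move the number up as well. For the measured compounds named here, no measured step here involves an aromatic ring, so the size is uncertain, but the expected step for compound 4 is an 11-fold higher number from compound 1 to compound 4 (1.05 log units; beyond the scatter). The estimate for compound 4 is 100 nM, with a range from 20 nM to 500 nM.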

Compound 4, half-maximal effective concentration: 851 nM
Beside the measured number, compound 4's estimate is 8.5-fold (0.93 log units) below it; measured number above the stated range.
By their numbers in this assay, from the lowest: compound 1; then compound 2; then compound 3; then compound 4.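

In this assay the change to 3-chlorophenyl on the carbonyl carbon gives a 96-fold higher number from compound 1 to compound 4 (1.98 log units; beyond the scatter) and this is the largest step seen so far at this position. The aromatic group also stands apart from the two other replacements of ethyl: the saturated ring of cyclobutyl gives way to it with a 10-fold higher number from compound 2 to compound 4 (1.02 log units; beyond the scatter) and methoxymethyl gives way to it with a 4.2-fold higher number from compound 3 to compound 4 (0.62 log units; beyond the scatter) so all three steps lie beyond the scatter and ethyl keeps the lowest number.

A plain phenyl group on the same carbonyl carbon would show how much of this rise goes with the aromatic ring and how much with the chlorine, and a methyl group would show whether anything shorter than ethyl lowers the number further. Nothing given here bears on the cause of these differences.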